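Notes on the acid side chain of compound 2

A few compounds are considered here, and "the series" means these few. Any claim that something is new, unique, unknown or untested is made for them only; others in the source may bear on it.

Three compounds have been run in a functional assay on CHO cells for antagonist activity at sphingosine 1-phosphate receptor 2 (Homo sapiens), read by calcium flux; on this read-out higher numbers stand for weaker inhibition and lower numbers for stronger inhibition. Compound 1 `O=C(Cc1nn(C2CCNC2)c(=O)c2ccccc12)Nc1ccc(OC(F)(F)F)c(Cl)c1` gives 94 nM. Compound 2 `C[C@@H](C(=O)O)c1nn(Cc2cn3cc(OCC4CC4)c(Cl)cc3n2)c2ccccc2c1=O` gives 24 nM, the lowest of the two numbers; the gap from compound 1 to compound 2 is beyond the usual scatter, so compound 2 stands as the stronger inhibitor of the two. Compound 3 `COc1cc(OC)c(NC(=O)Cc2cn(C)c3ccccc23)cc1Cl` gives only a limit in this assay, > 8130 nM, and not a number. That limit is the one noted as the limit of > 8130 nM in this assay, at which 1 of the 3 values shown sits.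

Compound 4 `O=C(O)Cc1nn(Cc2cn3cc(OCC4CC4)c(Cl)cc3n2)c2ccccc2c1=O` has not been measured yet. It differs from compound 2 in one place: hydrogen in place of methyl on a saturated chain carbon bound to an aromatic carbon and a carbonyl carbon. The carbonyl, the acid and the rest of compound 2 are kept as they are.

Among the compounds with values here, no pair of measured compounds shows a change of this kind, so the size of the step has no precedent here. A small move toward weaker inhibition in this assay is expected, most likely not beyond the scatter, though a move beyond it cannot be ruled out; the step from compound 2 to compound 4 is expected to be a 2.1-fold higher number from compound 2 to compound 4 (0.32 log units; beyond the scatter). Compound 4 is accordingly estimated at 50 nM, with a range from 15 nM to 200 nM.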

Compound 4, half-maximal inhibitory concentration: 20 nM
Compound 4: the middle estimate sits 2.5-fold (0.40 log units) above what was measured; measured number inside the range.
By their numbers in this assay, from the lowest: compounds 4 and 2 (each within the scatter of the next); then compound 1. At a limit, above all of these: compound 3.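

Within the data shown here, the change from 1-carboxyethyl to carboxymethyl, on a saturated chain carbon bound to an aromatic carbon and a carbonyl carbon, is the first one read at this position in this assay: a 1.2-fold lower number from compound 2 to compound 4 (0.08 log units; within the scatter). On this read-out compound 2 and compound 4 cannot be told apart, so the methyl of compound 2 is not required for inhibition in the nanomolar range seen for this pair, and the defined stereocentre of compound 2 is not required either. The data shown offer no reason for this flat step, and nothing measured on these compounds bears on it.

What remains open is how much room this carbon allows: an ethyl group, two methyl groups, or the opposite configuration of the methyl could each sit here, and the single step shown says nothing about any of them. The carboxylic acid is common to compound 2 and compound 4, so its part in the inhibition cannot be read from this pair, and a primary amide or a tetrazole in its place would be the direct test of that.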